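Hydroxamate series: aryl change on the carbonyl, compound 3 to 4

The source may report more compounds than this note shows. Statements on the series, on what has been measured and on what is new or still open speak of the compounds shown alone.

Measured so far in a functional assay on SK-N-AS cells (Homo sapiens) for antiproliferative activity, with a stated time of 72 h; on this read-out higher numbers stand for weaker inhibition and lower numbers for stronger inhibition:
- compound 1 `Cc1ccc(NC(=O)CCN(Cc2ccc(C(=O)NO)cc2)C(=O)c2cc(C)cc(C)c2)cc1`: 220 nM
- compound 2 `COc1cc(OC)cc(C(=O)N(CCC(=O)NCc2ccccc2)Cc2ccc(C(=O)NO)cc2)c1`: 9470 nM
- compound 3 `Cc1ccc(C(=O)N(CCC(=O)NCc2ccccc2)Cc2ccc(C(=O)NO)cc2)cc1`: 910 nM

Compound 3 stands second highest of the three numbers; its nearest neighbour is compound 1, whose number is lower, and its furthest is compound 2, whose number is higher. Among the compounds with values here, the only step measured at the carbonyl-bound aryl is a 10-fold lower number from compound 2 to compound 3 (1.02 log units; beyond the scatter), a large step, but it concerns a different pair of groups.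

Compound 4 `Cc1cc(C)cc(C(=O)N(CCC(=O)NCc2ccccc2)Cc2ccc(C(=O)NO)cc2)c1` differs from compound 3 in one place: 3,5-dimethylphenyl in place of 4-methylphenyl on a carbonyl carbon. Within the data shown here, no measured step covers this exact exchange. Compound 1 carries the same 3,5-dimethylphenyl on the carbonyl but a different amide partner, so its value and that of compound 3 only suggest that the entering group is tolerated at the lower end of the numbers seen. The expected step of a 1.5-fold lower number from compound 3 to compound 4 (0.18 log units; within the scatter) is therefore small, toward a lower number, and may lie within the scatter. Compound 4 is estimated at 600 nM, in the range 250 nM to 1500 nM.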

Compound 4, half-maximal inhibitory concentration: 1860 nM
For compound 4 the middle estimate is 3.1-fold (0.49 log units) below the measured one, and the stated range ends below it.
By their numbers in this assay, from the lowest: compound 1; then compound 3; then compound 4; then compound 2.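

On the carbonyl carbon in this assay, 3,5-dimethylphenyl in place of 4-methylphenyl gives a 2.0-fold higher number from compound 3 to compound 4 (0.31 log units; beyond the scatter) and 3,5-dimethylphenyl in place of 3,5-dimethoxyphenyl gives a 5.1-fold lower number from compound 2 to compound 4 (0.71 log units; beyond the scatter), so the three benzyl amides now fall in one order: 4-methylphenyl lowest, 3,5-dimethylphenyl next and 3,5-dimethoxyphenyl highest. With 3,5-dimethylphenyl held on the carbonyl, the group on the amide-type nitrogen also counts, as benzyl in place of 4-methylphenyl gives an 8.5-fold higher number from compound 1 to compound 4 (0.93 log units; beyond the scatter). Nothing at hand explains either change.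

Open, on these data alone, is whether the order of the three aryl groups holds when 4-methylphenyl replaces benzyl on the amide-type nitrogen. Also open, as far as these compounds go, is how an amine or a carboxylic acid on the carbonyl-bound ring would read in this assay.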